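Chlorine pattern on the amide aryl ring and cell growth

The source may report more compounds than this note shows. Statements on the series, on what has been measured and on what is new or still open speak of the compounds shown alone.

Compound 1 `O=C(Nc1ccc(Cl)c(-c2nnc3c(Cl)cccn23)c1)c1ccc(C(F)(F)F)cc1Cl`: in a functional assay on MDA-MB-231 cells (Homo sapiens) for antiproliferative activity, read by MTT assay, with stated times of 72 h and 4 h (on this read-out lower numbers stand for stronger inhibition and higher numbers for weaker inhibition), compound 1 gives > 100000 nM, which is a limit of the assay.
Compound 2 `O=C(Nc1ccc(Cl)c(-c2nnc3c(Cl)cccn23)c1)c1ccc(Cl)cc1`: in this assay compound 2 gives > 100000 nM, also a limit of the assay.
Compound 3 `O=C(Nc1ccc(Cl)c(-c2nnc3c(Cl)cccn23)c1)c1cccc(Cl)c1`: in this assay compound 3 gives 66100 nM.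

Compound 3 is thus the only one of the three with an actual number; the other two sit at the limit of > 100000 nM in this assay, at which 2 of the 3 values shown sit. Within the data shown here, the single measured step between neighbours is an at least 1.5-fold lower number from compound 2 to compound 3 (0.17 log units; that floor lies within the scatter), and even that floor lies within the ordinary scatter of this assay, so the three compounds are barely distinguishable.

Compound 4 `O=C(Nc1ccc(Cl)c(-c2nnc3c(Cl)cccn23)c1)c1ccc(Cl)cc1Cl` differs from compound 3 by 2,4-dichlorophenyl in place of 3-chlorophenyl on a carbonyl carbon. Among the measured compounds shown here, no measured step covers this exact change. What bears on it is that compound 2, carrying 4-chlorophenyl, and compound 1 both sit at the limit, while compound 3 with 3-chlorophenyl is only just inside the measurable range. Compound 4 keeps the chlorine of the 4-chlorophenyl pattern and adds a second, so it is expected to move back toward the limit, a step of a 1.5-fold higher number from compound 3 to compound 4 (0.18 log units; within the scatter) to weaker inhibition. The estimate for compound 4 in this assay is 100000 nM, with a range from 40000 nM to 300000 nM, and the most likely outcome is that only a limit is reported.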

Compound 4, half-maximal inhibitory concentration: > 100000 nM
Compound 4 gave a limit, no number (the forecaster's own chance of this, stated with the estimate: 70%); the middle value lies on the limit itself.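

On the carbonyl carbon, 2,4-dichlorophenyl in place of 3-chlorophenyl gives an at least 1.5-fold higher number from compound 3 to compound 4 (0.17 log units; that floor lies within the scatter). This is only a floor, so the true size of the change could be larger, but what can be read does not separate the two compounds beyond the ordinary scatter of this assay. The steps to compound 4 from compound 2 and from compound 1 cannot be read, as each joins two limits, but the new result does show that a ring carrying both chlorines also ends at a limit, leaving compound 3 as the only compound with a number and most of the set at the ceiling: the limit of > 100000 nM in this assay, at which 3 of the 4 values shown sit.

From the compounds shown here alone, it remains open whether the lone number of compound 3, 66100 nM, marks any real difference from the other three compounds, or whether all four simply have very weak effects on these cells. Also open, going by these compounds, is what an amine or a carboxylic acid on this aromatic ring would do, or a longer chain on the carbonyl carbon in place of the ring.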